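Series notes: removing the 5-methylthiophen-2-yl group

This account rests on a few compounds, and the source may have more. Where it says the series, first, only, none or still open, it means among the compounds named here.

Compound 1 `CCOc1cc(NC(=O)CCCCC(=O)Nc2cc(-c3ccc(C)s3)ccc2N)cc2c1OCC([N+](=O)[O-])=C2` and compound 2 `CCOc1cc(NC(=O)CCCCC(=O)Nc2ccccc2N)cc2c1OCC([N+](=O)[O-])=C2` share one core and differ in a single place: hydrogen in place of 5-methylthiophen-2-yl on an aromatic carbon. In a functional assay on PC-3 cells (Homo sapiens) for antiproliferative activity, read by MTT assay, with a stated time of 48 h (on this read-out higher numbers stand for weaker inhibition of growth and lower numbers for stronger inhibition of growth), compound 1 gives 13500 nM, and compound 2 gives 18900 nM; the step between them is a 1.4-fold higher number from compound 1 to compound 2 (0.15 log units; within the scatter). Compound 3 `CCOc1cc(NC(=O)CCCCCC(=O)Nc2cc(-c3ccc(C)s3)ccc2N)cc2c1OCC([N+](=O)[O-])=C2` gives 11400 nM in this assay; the difference between the core of compound 3 and the core of compound 1 is not broken down here, and the two values lie within the scatter of each other. Compound 4 `CCOc1cc(NC(=O)CCCCCC(=O)Nc2ccccc2N)cc2c1OCC([N+](=O)[O-])=C2` has not yet been measured. It differs from compound 3 in one place: hydrogen in place of 5-methylthiophen-2-yl on an aromatic carbon. This is the same change as from compound 1 to compound 2, at a place described in the same words. In this assay the expected step is a 1.4-fold higher number from compound 3 to compound 4 (0.15 log units; within the scatter). Going by the values given here, this expectation rests on the single earlier instance of the change, a 1.4-fold higher number from compound 1 to compound 2 (0.15 log units; within the scatter), which stayed within the scatter. Compound 4 is thus estimated at 16000 nM, with a range from 9000 nM to 30000 nM.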

Compound 4, concentration for 50% growth inhibition: > 20000 nM
Compound 4: no number, only a limit (the forecaster's own chance of this, stated with the estimate: 10%); middle value at least 1.2-fold (0.09 log units) away from the limit.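

In this assay compound 4 gives > 20000 nM, which is a limit of the assay and not a number. On the core of compound 3, removing the 5-methylthiophen-2-yl group gives an at least 1.7-fold higher number from compound 3 to compound 4 (0.24 log units; that floor lies within the scatter), so this instance can be set beside the earlier one only through a floor: the same change on two cores in this assay, a 1.4-fold higher number (0.15 log units; within the scatter) from compound 1 to compound 2 and an at least 1.7-fold higher number (0.24 log units; that floor lies within the scatter) from compound 3 to compound 4; the limit leaves it open whether they differ. The result fits the change carrying over from one core to the other but does not show that its size is the same on both, and the chain change, an at least 1.0-fold higher number from compound 2 to compound 4 (0.02 log units; that floor lies within the scatter), is likewise readable only as a floor.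

From the compounds shown here alone, the actual size of the step on the core of compound 3 stays open, as does whether the change can reach beyond the scatter on either core. Also open, going by these compounds, is how a phenyl group or an unsubstituted thiophen-2-yl group would read in the same place, and whether the change behaves alike on a longer chain.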